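Phenoxy in place of triazolylmethyl on the shared core

This account rests on a few compounds, and the source may have more. Where it says the series, first, only, none or still open, it means among the compounds named here.

Compound 1 `Cc1c(Cc2ccccc2S(=O)(=O)C2CCCCC2)c2c(n1CC(=O)O)CCNC2=O` and compound 2 `Cc1c(Cc2ccccc2Cn2ccnn2)c2c(n1CC(=O)O)CCNC2=O` share one core. For the measured compounds named here, in a functional assay on CHO.K1 cells for antagonist activity at prostaglandin D2 receptor 2 (Homo sapiens), read by GTPgammaS binding, with a stated time of 1 h (on this read-out lower numbers stand for stronger inhibition and higher numbers for weaker inhibition), compound 1 gives 28 nM, while compound 2 gives 800 nM, the higher of the two numbers; the single step, a 29-fold higher number from compound 1 to compound 2 (1.46 log units; beyond the scatter), separates them. Compound 3 `Cc1c(Cc2ccccc2Oc2ccccc2)c2c(n1CC(=O)O)CCNC2=O` differs from compound 2 by phenoxy in place of (1H-1,2,3-triazol-1-yl)methyl on an aromatic carbon. Going by the values given here, no measured step involves phenoxy itself; the one step, a 29-fold higher number from compound 1 to compound 2 (1.46 log units; beyond the scatter), shows only that the group at this place shifts the number widely. Compound 3 is therefore expected to move downward, by an 8.0-fold lower number from compound 2 to compound 3 (0.90 log units; beyond the scatter). The estimate for compound 3 is 100 nM, within 20 nM to 500 nM.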

Compound 3, half-maximal inhibitory concentration: 530 nM
Beside the measured number, compound 3's estimate is 5.3-fold (0.72 log units) below it; measured number outside the range, above it.
By their numbers in this assay, from the lowest: compound 1; then compounds 3 and 2 (each within the scatter of the next).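

In this assay the step to phenoxy gives a 1.5-fold lower number from compound 2 to compound 3 (0.18 log units; within the scatter), so two groups that differ in their ring and in their counted acceptors cannot be told apart at this place. Replacing cyclohexylsulfonyl with phenoxy gives a 19-fold higher number from compound 1 to compound 3 (1.28 log units; beyond the scatter), which shows that the large shift seen earlier is not confined to the triazolylmethyl group. Nothing available accounts for these numbers. On these data alone, whether phenylsulfonyl or cyclohexyloxy at this place would stay near compound 1 or near compound 3 remains open, so it is unsettled which part of cyclohexylsulfonyl goes with the lower number.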